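Compound 4: phenylethenyl in place of methanesulfonamidophenyl

The compounds below may be only part of what the source reports. "The series", "measured", "known", "first", "only" and "open" are said of these compounds alone.

Compound 1 `CC(C)(N)C(=O)N[C@H](COCc1ccccc1)c1nnn(Cc2ccccc2)n1` carries a plain aromatic ring on the saturated chain carbon bound to an aromatic nitrogen; in an assay on isolated protein for displacement of a labelled ligand from growth hormone secretagogue receptor type 1 (Homo sapiens), with a stated time of 1 h (on this read-out higher numbers stand for weaker inhibition and lower numbers for stronger inhibition), compound 1 gives 4750 nM. Compound 2 `CC(C)(N)C(=O)N[C@H](COCc1ccccc1)c1nnn(Cc2cccc(NS(C)(=O)=O)c2)n1` adds a methanesulfonamido group to that ring. In this assay compound 2 reaches only a limit, > 5000 nM. Compound 3 `CC(C)(N)C(=O)N[C@H](COCc1ccccc1)c1nnn(Cc2ccccc2NS(C)(=O)=O)n1` carries the methanesulfonamido group at a different position of the same ring. In this assay compound 3 also stands at a limit, > 5000 nM, so it has no number of its own among the values shown. The steps of an at least 1.0-fold higher number from compound 1 to compound 2 (0.02 log units; that floor lies within the scatter) and an at least 1.0-fold higher number from compound 1 to compound 3 (0.02 log units; that floor lies within the scatter) are floors only, both ending at the limit of > 5000 nM in this assay, at which 2 of the 3 values shown sit, and the step that the two limits leave unreadable from compound 2 to compound 3 cannot be read.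

Compound 4 `CC(C)(N)C(=O)N[C@H](COCc1ccccc1)c1nnn(C/C=C/c2ccccc2)n1` differs from compound 3 by 2-phenylethenyl in place of 2-(methanesulfonamido)phenyl on a saturated chain carbon bound to an aromatic nitrogen. Among the compounds with values here, no measured step makes a change of this kind; the measured steps show only that adding a methanesulfonamido group did not lower the number, and they say nothing about removing it or about a phenylethenyl arm. The nearest reference is compound 1, which has no methanesulfonamido group and gives 4750 nM. Compound 4 is therefore expected to return from the limit to a number near that of compound 1, the expected step being an at least 1.2-fold lower number from compound 3 to compound 4 (0.09 log units; that floor lies within the scatter). The estimate for compound 4 is 4000 nM, with a range from 1000 nM to 15000 nM.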

Compound 4, inhibition constant: > 5000 nM
Compound 4 gave a limit, no number; the forecaster's own chance of this, stated with the estimate: 40%; at least 1.2-fold (0.09 log units) between middle value and limit.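

Compound 4 also stands at a limit in this assay, > 5000 nM, and it carries an arm with no methanesulfonamido group, no hydrogen-bond donor and no hydrogen-bond acceptor. Limits at this position are therefore no longer confined to arms bearing methanesulfonamido, and the only readable comparison, an at least 1.0-fold higher number from compound 1 to compound 4 (0.02 log units; that floor lies within the scatter), is a floor that does not separate 2-phenylethenyl from the plain phenyl of the reference. The steps to compound 4 from compound 2 and from compound 3 cannot be read, since both ends of each are limits, and this leaves most of the set at one boundary with little to rank the arms on the saturated chain carbon bound to an aromatic nitrogen: the limit of > 5000 nM in this assay, at which 3 of the 4 values shown sit.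

The compounds shown leave open whether any group at this position can bring the read-out clearly below that boundary, for example an amine or a carboxylic acid on the aromatic ring, or a longer saturated chain carrying the phenyl. They also leave open how far the arms differ from one another beyond the limit, which would take a parent with a measurable number in this assay to show.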